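Swapping a Bromophenyl for Furan-2-yl: An Estimate

The source may hold more compounds than are shown below. What is called first, only, known or untested is meant among the compounds shown, and "the series" means these compounds.

Compound 1 `O=C(CSc1nnc(-c2ccncc2)o1)N/N=C/c1ccc(Br)cc1`: 19100 nM
Compound 2 `O=C(CSc1nnc(-c2ccncc2)o1)N/N=C/c1ccccc1F`: 21800 nM
Compound 3 `O=C(CSc1nnc(-c2ccncc2)o1)N/N=C/c1cc(Cl)ccc1O`: 5830 nM

Of the compounds shown here, three sharing one core have been measured in a functional assay on MCF7 cells (Homo sapiens) for cytotoxicity, read by MTT assay, with a stated time of 48 h; a higher number here means a weaker inhibitor, a lower number a stronger inhibitor. Compound 1 gives 19100 nM, the second highest of the three numbers; compound 2 lies nearest, with a 1.1-fold higher number from compound 1 to compound 2 (0.06 log units; within the scatter), and compound 3 lies furthest, with a 3.3-fold lower number from compound 1 to compound 3 (0.52 log units; beyond the scatter). Between the other two the step is a 3.7-fold lower number from compound 2 to compound 3 (0.57 log units; beyond the scatter).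

Compound 4 `O=C(CSc1nnc(-c2ccncc2)o1)N/N=C/c1ccco1` has not yet been measured. It differs from compound 1 in one place: furan-2-yl in place of 4-bromophenyl on a carbon with a double bond to nitrogen. Both measured steps from compound 1 change the same place and therefore bear on this one. Exchanging one six-membered aromatic ring for another gave at most a modest shift, and only where 5-chloro-2-hydroxyphenyl entered, as in compound 3. Among the compounds with values here, no measured step introduces a five-membered aromatic ring with a hetero atom, so the new change has no close precedent. On that basis compound 4 is expected to stay near compound 1, with an estimated step of a 1.1-fold lower number from compound 1 to compound 4 (0.03 log units; within the scatter) that is not expected to exceed the scatter. The estimate for compound 4 in this assay is 18000 nM, within a range from 7000 nM to 45000 nM.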

Compound 4, half-maximal inhibitory concentration: 16600 nM
Estimate against measurement, compound 4: 1.1-fold (0.04 log units) above; the range from low to high includes it.
By their numbers in this assay, from the lowest: compound 3; then compounds 4, 1 and 2 (each within the scatter of the next).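

In this assay, the place on a carbon with a double bond to nitrogen takes a five-membered aromatic ring with 1 hetero atom without a shift beyond the scatter from a six-membered aromatic ring of carbon only, as shown by a 1.2-fold lower number from compound 1 to compound 4 (0.06 log units; within the scatter) and by a 1.3-fold lower number from compound 2 to compound 4 (0.12 log units; within the scatter) for the two phenyl groups with a single halogen. Neither the change of ring size nor the hydrogen-bond acceptor that furan-2-yl brings in place of 4-bromophenyl moves the number measurably, whereas 5-chloro-2-hydroxyphenyl stays apart from furan-2-yl as well, with a 2.8-fold higher number from compound 3 to compound 4 (0.45 log units; beyond the scatter) making compound 3 the strongest of the four. Nothing measured here accounts for why this one group stands apart.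

The compounds shown leave open whether the lower number of compound 3 goes with its hydroxyl or its chlorine, which a plain 2-hydroxyphenyl would help to separate, and whether the oxygen of furan-2-yl matters, which thiophen-2-yl, with sulfur in its place, could test. Also open, from the compounds shown here alone, is how this place responds to a different kind of group, such as an aliphatic amine or a carboxylic acid.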